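A Smaller Alkyl Group on an Antiproliferative Scaffold

The source may report more compounds than this note shows. Statements on the series, on what has been measured and on what is new or still open speak of the compounds shown alone.

Compound 1 `N=C(NC(=N)NC1CCCC1)Nc1ccc(C(F)(F)F)cc1` holds the lowest of the two numbers recorded so far in a functional assay on A2780 cells (Homo sapiens) for antiproliferative activity, read by MTT assay, with a stated time of 72 h (a higher number here means a weaker inhibitor, a lower number a stronger inhibitor), with compound 1 measured at 2500 nM. Compound 2 `CC(C)CNC(=N)NC(=N)Nc1ccc(F)cc1F` gives 19800 nM, a gap beyond the usual scatter; since the two differ in more than one place, only their values can be set side by side. Compound 3 `CC(C)NC(=N)NC(=N)Nc1ccc(C(F)(F)F)cc1` differs from compound 1 in one place: isopropyl in place of cyclopentyl on an amine nitrogen. Among the compounds with values here, no measured pair shows this change. A modest loss of potency is expected, a 2.0-fold higher number from compound 1 to compound 3 (0.30 log units; within the scatter), though a result within the scatter would not surprise. Compound 3 is expected to give 5000 nM, within 1500 nM to 20000 nM.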

Compound 3, half-maximal inhibitory concentration: 3200 nM
The estimate for compound 3 lay 1.6-fold (0.19 log units) above the measured number, and the stated range covers the measured number.
By their numbers in this assay, from the lowest: compounds 1 and 3 (each within the scatter of the next); then compound 2.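

In this assay, within the data shown here, the change to isopropyl from cyclopentyl on this amine nitrogen gives a 1.3-fold higher number from compound 1 to compound 3 (0.11 log units; within the scatter) as the first direct reading at this position, which the values of compound 1 and compound 2 alone could not provide. Within the scatter, this position tolerates the open isopropyl group in place of the carbon ring, despite the smaller heavy-atom count. Nothing available here explains why the two groups read alike. As far as these compounds go, what a cyclohexyl ring, a tert-butyl group or a longer chain ending in a hydroxyl group would give on this nitrogen remains open.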